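Cytotoxicity notes: hydroxy for nitro on compound 1

The source may report more compounds than this note shows. Statements on the series, on what has been measured and on what is new or still open speak of the compounds shown alone.

Compound 1 `O=[N+]([O-])c1ccc(-c2nc3cc(Cl)c(Cl)cc3[nH]2)cc1`: >= 100000 nM
Compound 2 `CC(=O)Nc1ccc(-c2nc3cc([N+](=O)[O-])ccc3[nH]2)cc1`: > 100000 nM
Compound 3 `CCN(CC)CC(=O)Nc1ccc(-c2nc3cc(C(F)(F)F)ccc3[nH]2)cc1`: 24000 nM

All three values come from an ADME assay on Vero cells (Chlorocebus sabaeus) for cytotoxicity; on this read-out higher numbers stand for lower toxicity in this test and lower numbers for higher toxicity in this test. The result for compound 1 is a limit of the assay and not a number, >= 100000 nM. The result for compound 2 is likewise a limit, > 100000 nM. Only compound 3 gives a measured number in this assay, 24000 nM. So compound 1 stands at the upper edge of what this assay reports, and it is not alone there: one further value sits at a limit (the limit of > 100000 nM in this assay, at which 1 of the 3 values shown sits), and compound 1 itself sits at the other (the limit of >= 100000 nM in this assay, at which 1 of the 3 values shown sits). For the measured compounds named here, no pairs of measured compounds differ in a single place, so no measured step is available to size the change.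

Compound 4 `Oc1ccc(-c2nc3cc(Cl)c(Cl)cc3[nH]2)cc1` carries the shared core of compound 1 with hydroxy in place of nitro on an aromatic carbon. Going by the values given here, no measured step fits this change, so the expectation rests on the position of compound 1 alone. It is expected that the step of an at least 1.2-fold lower number from compound 1 to compound 4 (0.09 log units; that floor lies within the scatter) stays within the scatter, most likely ending again at or near the limit. For compound 4 the estimated value is 80000 nM, with a range from 20000 nM to 200000 nM.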

Compound 4, half-maximal cytotoxic concentration: 18000 nM
The estimate for compound 4 lay 4.4-fold (0.65 log units) above the measured number, outside the stated range (below it).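

The position is not silent in this assay: with the shared core held fixed, hydroxy in place of nitro on an aromatic carbon, para to a large group, gives an at least 5.5-fold lower number from compound 1 to compound 4 (0.74 log units; beyond the scatter). For the compounds shown here, a change at this one place is thus enough to bring compound 4 off the upper edge of the read-out to a measured number, 18000 nM, and the earlier compounds, among which no pair differed in a single place, could not show this. The step can be sized only from one side, because the value of compound 1 is a limit of the assay and not a number: the limit of >= 100000 nM in this assay, at which 1 of the 4 values shown sits.

Going by these compounds alone, the single pair leaves open whether the drop goes with the arrival of hydroxy or with the departure of nitro, and an amine, a methoxy group or a carboxylic acid at the same place would help to tell these apart. Whether the same exchange gives a step of similar size on a core with other substituents also stays open, as the compounds shown hold only this one pair.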